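The source may report more compounds than this note shows. Statements on the series, on what has been measured and on what is new or still open speak of the compounds shown alone.

Compound 1 `O=[N+]([O-])c1ccc(Nc2nccc(-c3ccc(F)cc3)n2)cc1`: 7950 nM
Compound 2 `COc1cccc(Nc2nccc(-c3ccc(Br)cc3)n2)c1`: 148000 nM
Compound 3 `Cc1cccc(Nc2nccc(-c3ccc(Cl)cc3Cl)n2)c1`: 13200 nM

These three compounds were tested in a functional assay on HepG2 cells (Homo sapiens) for antiproliferative activity, read by MTT assay; on this read-out lower numbers stand for stronger inhibition and higher numbers for weaker inhibition. Among them compound 1 has the lowest number; compound 3 lies close by, within the usual scatter of repeated measurements, so these two cannot be ranked against each other, while compound 2 gives a markedly higher number that lies well beyond the scatter. Compound 4, `O=[N+]([O-])c1ccc(Nc2nccc(-c3ccc(Cl)c(Cl)c3)n2)cc1`, has not yet been measured. It differs from compound 1 in one place: 3,4-dichlorophenyl in place of 4-fluorophenyl on an aromatic carbon. Within the data shown here, no two measured compounds differ in only one place, so there is no measured step to lean on for this change. What can be said is that compound 1 and compound 3, which differ in more than one place, still give numbers within the scatter of each other. The expected step is therefore a 1.0-fold higher number from compound 1 to compound 4 (0.00 log units; within the scatter), a change no larger than the scatter in either direction. Compound 4 is estimated to give 8000 nM in this assay, with a likely range from 2500 nM to 25000 nM.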

Compound 4, half-maximal inhibitory concentration: 500 nM
Compound 4: middle estimate off by 16-fold (1.20 log units), on the high side; the measured number lies below the stated range.
By their numbers in this assay, from the lowest: compound 4; then compounds 1 and 3 (each within the scatter of the next); then compound 2.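

Replacing 4-fluorophenyl with 3,4-dichlorophenyl gives a 16-fold lower number from compound 1 to compound 4 (1.20 log units; beyond the scatter) in this assay. Among these compounds, with the rest of the molecule unchanged, this shows that the group on this aromatic carbon can shift the number far beyond the scatter, which the earlier compounds could not show because each pair differed in more than one place. Nothing measured here explains why this swap has so large an effect.

The change also combines two things, a different halogen and a second halogen on the phenyl ring, and these compounds do not separate them. A phenyl ring carrying a single chlorine would be needed to divide the step, while a ring carrying an amine or a carboxylic acid would test whether anything other than a halogen is tolerated on this carbon.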